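Phenylsulfonyl for 3-Chlorobenzyl on an Aromatic Nitrogen

The compounds below may be only part of what the source reports. "The series", "measured", "known", "first", "only" and "open" are said of these compounds alone.

Compound 1 `C#CCNC1CCc2c(OCCCCN3CCN(c4cccc5c4ccn5Cc4cccc(Cl)c4)CC3)cccc21` and compound 2 `C#CCNC1CCc2c(OCCCCN3CCN(c4cccc5c4ccn5S(=O)(=O)c4ccccc4)CC3)cccc21` share one core; compound 3 `C#CCN(C)Cc1ccc(OCCCCCN2CCN(c3cccc4c3ccn4Cc3cccc(Cl)c3)CC2)cc1` and the not yet measured compound 4 `C#CCN(C)Cc1ccc(OCCCCCN2CCN(c3cccc4c3ccn4S(=O)(=O)c3ccccc3)CC2)cc1` share another, and the difference between the two cores is not broken down here. In an assay on BTI cells for inhibition of Amine oxidase [flavin-containing] B (Homo sapiens), read by fluorescence, with stated times of 30 min and 1 h (a lower number here means a stronger inhibitor, a higher number a weaker inhibitor), compound 1 gives 270 nM. For compound 2 the assay reports only a limit, > 1000 nM. The change is phenylsulfonyl in place of 3-chlorobenzyl on an aromatic nitrogen, and it brought an at least 3.7-fold higher number from compound 1 to compound 2 (0.56 log units; beyond the scatter), a step that rests on (the limit of > 1000 nM in this assay, at which 1 of the 3 values shown sits). Compound 3 gives 30 nM in this assay, with compound 1 giving the higher number.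

The same kind of change, (phenylsulfonyl in place of 3-chlorobenzyl on an aromatic nitrogen), leads from compound 3 to compound 4. Compound 4 is expected to show a step of a 6.7-fold higher number from compound 3 to compound 4 (0.82 log units; beyond the scatter), because the earlier change gave an at least 3.7-fold higher number from compound 1 to compound 2 (0.56 log units; beyond the scatter). Compound 4 is therefore estimated at 200 nM in this assay, likely between 60 nM and 800 nM.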

Compound 4, half-maximal inhibitory concentration: 154 nM
Compound 4: middle estimate off by 1.3-fold (0.11 log units), on the high side, within the range that was stated.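

In this assay, phenylsulfonyl in place of 3-chlorobenzyl on an aromatic nitrogen brought a 5.1-fold higher number from compound 3 to compound 4 (0.71 log units; beyond the scatter), so on this second core the change again moved the number toward a weaker inhibitor. Set side by side, the two steps run in the same direction, which is as far as the comparison between the two cores reaches: the same change on two cores in this assay, an at least 3.7-fold higher number (0.56 log units; beyond the scatter) from compound 1 to compound 2 and a 5.1-fold higher number (0.71 log units; beyond the scatter) from compound 3 to compound 4; the limit leaves it open whether they differ. Compound 2 is reported only as a limit, so the pair shows that the direction carried over from one core to the other, but not that the size of the step did, and it says nothing about any further core: the limit of > 1000 nM in this assay, at which 1 of the 4 values shown sits.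

The compounds shown leave open whether the step would look the same with other groups on the aromatic nitrogen, such as a plain benzyl, a methyl or an acetyl, or with a 3-chlorophenylsulfonyl group. They also leave open whether it would hold on a core with a longer chain or with a different amine.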